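An Ethyl Group on the Carboxamide of Compound 1

A few compounds are considered here, and "the series" means these few. Any claim that something is new, unique, unknown or untested is made for them only; others in the source may bear on it.

Compound 1, `CC[C@@H]1C(=O)N(C)c2cnc(-n3ccc4cc(C(N)=O)ccc43)nc2N1C1CCCC1`, gives 3090 nM in a functional assay on Huh-7 cells (Homo sapiens) for antiproliferative activity, read by CCK-8 assay, with a stated time of 72 h (on this read-out higher numbers stand for weaker inhibition of growth and lower numbers for stronger inhibition of growth), the higher of the two numbers recorded so far; compound 2, `CCCCNS(=O)(=O)c1ccc(Nc2ncc3c(n2)N(C2CCCC2)[C@H](CC)C(=O)N3C)cc1`, gives 225 nM in this assay. Compound 3, `CCNC(=O)c1ccc2c(ccn2-c2ncc3c(n2)N(C2CCCC2)[C@H](CC)C(=O)N3C)c1`, differs from compound 1 by ethyl in place of hydrogen on an amide-type nitrogen. Among the compounds with values here, no measured pair shows this change on its own, so its effect is unknown from these numbers. The step of a 1.5-fold lower number from compound 1 to compound 3 (0.19 log units; within the scatter) is expected to be small, within the scatter or only slightly toward stronger inhibition. Compound 3 is therefore estimated at 2000 nM, with a range from 600 nM to 6000 nM.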

Compound 3, concentration for 50% growth inhibition: 596 nM
The estimate for compound 3 lay 3.4-fold (0.53 log units) above the measured number; measured number outside the range, below it.
By their numbers in this assay, from the lowest: compound 2; then compound 3; then compound 1.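

In this assay, within the data shown here, ethyl in place of hydrogen on the amide-type nitrogen gives a 5.2-fold lower number from compound 1 to compound 3 (0.71 log units; beyond the scatter) and is the first measured change at this position. The nitrogen of the carbamoyl group thus accepts a substituent, and in this pair ethylcarbamoyl goes with stronger inhibition of growth than carbamoyl. Nothing at hand accounts for the gain. Going by these compounds, whether a longer chain such as butyl or a ring such as cyclopropyl on this nitrogen goes further remains open. So does what a carboxylic acid in place of the carboxamide would give.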